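Ring opening from compound 2 to compound 3

A few compounds are considered here, and "the series" means these few. Any claim that something is new, unique, unknown or untested is made for them only; others in the source may bear on it.

Measured in a functional assay on NCI-H460 cells (Homo sapiens) for inhibition, read by MTT assay, with a stated time of 24 h, tested at 1 ug/mL; a lower number here means less inhibition of growth, a higher number more inhibition of growth at the concentration tested
compound 1 `O=C(CCCCC1CCSS1)Nc1ccccn1` gives 0.81%
compound 2 `O=C(CCCCC1CCSS1)Nc1ccc(Cl)cn1` gives 6.26%

Going by the values given here, compound 2 stands within the scatter of compound 1, the only other measured compound. Compound 3 `O=C(CCCCC(S)CCS)Nc1ccc(Cl)cn1` is still unmeasured and carries one change (a group of 5 heavy atoms (3 carbon, 2 sulfur; no ring) in place of a group of 5 heavy atoms (3 carbon, 2 sulfur; one five-membered non-aromatic ring with 2 hetero atoms), on a saturated chain carbon, four bonds along the chain from a carbonyl carbon) on a saturated chain carbon, four bonds along the chain from a carbonyl carbon. Among the compounds with values here, the sole measured step (a number 5.5 percentage points higher from compound 1 to compound 2 (within the scatter)) is chloro in place of hydrogen on an aromatic carbon, a different change, and offers only weak guidance. No step beyond the scatter is therefore expected in this assay, and the estimated step (a number 2.7 percentage points higher from compound 2 to compound 3 (within the scatter)) reflects that. For compound 3 the expected value is 9% with an estimated range of 0% to 25% as the working figure.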

Compound 3, percent growth inhibition at one concentration: "not active" (no number reported)
Compound 3 has no reported number here; there is nothing to compare the estimate with.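

Going by these compounds alone, compound 3 is reported as "not active" without a number in this assay, so no step from compound 2 to compound 3 can be read. No measurement here bears on this result. The compounds shown leave open how the 1,3-disulfanylpropyl group compares numerically with the ring it replaces.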